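Swapping 2-methoxyphenyl for benzyl on the aromatic nitrogen

The source may report more compounds than this note shows. Statements on the series, on what has been measured and on what is new or still open speak of the compounds shown alone.

Compound 1 `Cc1ccc2nc(NC(=O)CSc3nc4c(c(=O)n3-c3ccc(F)cc3)SCC4)sc2c1`: > 10000 nM (a limit)
Compound 2 `COc1ccccc1-n1c(SCC(=O)Nc2nc3ccc(C)cc3s2)nc2c(c1=O)SCC2`: 230 nM

Within the data shown here, in a functional assay on CAPAN-1 cells (Homo sapiens) for antiproliferative activity, read by MTT assay, with a stated time of 48 h (on this read-out higher numbers stand for an effect only at larger amounts of compound and lower numbers for an effect already at smaller amounts), compound 2 gives 230 nM, the only actual number so far. Compound 1 is reported only as a limit, > 10000 nM. Compound 3 `Cc1ccc2nc(NC(=O)CSc3nc4c(c(=O)n3Cc3ccccc3)SCC4)sc2c1` has not yet been measured, and its structure differs at one place: benzyl in place of 2-methoxyphenyl on an aromatic nitrogen. Among the measured compounds shown here, one measured step bears on this aromatic nitrogen, an at least 43-fold lower number from compound 1 to compound 2 (1.63 log units; beyond the scatter), and it was large. A higher number is therefore expected on leaving 2-methoxyphenyl, as a clear but smaller move, estimated as a 6.5-fold higher number from compound 2 to compound 3 (0.81 log units; beyond the scatter). For compound 3 the expected value in this assay is 1500 nM, with an estimated range from 250 nM to 10000 nM.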

Compound 3, half-maximal effective concentration: > 10000 nM
Compound 3: a limit, no number; the forecaster's own chance of this, stated with the estimate: 20%; at least 6.6-fold (0.82 log units) between middle value and limit.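

In this assay, benzyl in place of 2-methoxyphenyl on the aromatic nitrogen gives an at least 43-fold higher number from compound 2 to compound 3 (1.63 log units; beyond the scatter), so keeping a six-membered aromatic ring of carbon only at this position does not preserve the effect. Among the three compounds, only the one carrying 2-methoxyphenyl gives an actual number, and the 4-fluorophenyl and benzyl compounds both stop at a limit: the limit of > 10000 nM in this assay, at which 2 of the 3 values shown sit.

Among these compounds, no step between compound 1 and compound 3 can be read, since both values are limits. Going by these compounds, whether the methoxy group of 2-methoxyphenyl is what counts remains open. So does how plain phenyl or 2-hydroxyphenyl on this nitrogen would read.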